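The source may report more compounds than this note shows. Statements on the series, on what has been measured and on what is new or still open speak of the compounds shown alone.

Working notes on the series.

Three compounds with the shared core have been run in a functional assay on MCF7 cells (Homo sapiens) for inhibition, read by sulforhodamine B assay, with a stated time of 72 h; on this read-out lower numbers stand for stronger inhibition and higher numbers for weaker inhibition. Compound 3, `CC(C)Cc1ccc(C(C)c2nnc3n2N=C(c2ccc(C(F)(F)F)cc2)CS3)cc1`, gives 4200 nM. Compound 1, `Cc1ccc(C2=Nn3c(nnc3C(C)c3ccc(CC(C)C)cc3)SC2)cc1`, differs from compound 3 only by methyl in place of trifluoromethyl on an aromatic carbon; in this assay compound 1 gives 6300 nM, and the step is a 1.5-fold higher number from compound 3 to compound 1 (0.18 log units; within the scatter). Compound 2, `COc1ccc2cc(C(C)c3nnc4n3N=C(c3ccc(C(F)(F)F)cc3)CS4)ccc2c1`, carries a different aryl on the side chain; the difference between the core of compound 2 and the core of compound 3 is not broken down here. In this assay compound 2 gives 6900 nM, and all three numbers sit within the usual scatter of one another, so no order among them is claimed.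

Compound 4, `COc1ccc2cc(C(C)c3nnc4n3N=C(c3ccc(C)cc3)CS4)ccc2c1`, is not yet measured. It stands to compound 2 as compound 1 stands to compound 3: the change is methyl in place of trifluoromethyl on an aromatic carbon, the same change at the same place. For the measured compounds named here, with only one measured instance of this change, the expectation rests on that single step, which was a 1.5-fold higher number from compound 3 to compound 1 (0.18 log units; within the scatter) and within the scatter. The step from compound 2 to compound 4 in this assay is therefore expected to be about as small, a 1.3-fold higher number from compound 2 to compound 4 (0.12 log units; within the scatter), and to stay within the scatter. Going by the values given here, compound 4 is estimated at 9000 nM in this assay, with the plausible range running from 4000 nM to 20000 nM; the breadth of that range reflects that compound 2 sits at 6900 nM and that only one prior step supports the transfer.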

Compound 4, half-maximal inhibitory concentration: 11000 nM
Estimate against measurement, compound 4: 1.2-fold (0.09 log units) below, within the range that was stated.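

In this assay, methyl in place of trifluoromethyl on an aromatic carbon gives a 1.6-fold higher number from compound 2 to compound 4 (0.20 log units; within the scatter), and this step can be set beside the one on the other core: the same change on two cores in this assay, a 1.5-fold higher number (0.18 log units; within the scatter) from compound 3 to compound 1 and a 1.6-fold higher number (0.20 log units; within the scatter) from compound 2 to compound 4, 1.1-fold (0.03 log units) apart, within the scatter of two such steps. Across these two cores, then, the change carries over as a step of the same small size, and the two steps cannot be told apart. This does not show that methyl and trifluoromethyl differ in this assay, as each step on its own lies within the scatter; the agreement is between two small steps on two cores, and it says nothing about how the change would behave on any other core.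

The compounds shown leave open how this assay would read with a group of a different kind at the same place on the aromatic ring, such as an amine, a carboxylic acid or a longer chain in place of methyl. For the compounds shown here, they also leave open whether any single change on the shared core would produce a step beyond the scatter, since the only steps available here are these two.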